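A few compounds are considered here, and "the series" means these few. Any claim that something is new, unique, unknown or untested is made for them only; others in the source may bear on it.

Three analogues of the shared core differ only in the group on the ring amine nitrogen. Compound 1 `CCCCCCN1CCC(C(=O)Nc2cc(Cl)c(N)cc2OC)CC1` carries a hexyl chain there. In a functional assay on the whole organism for antagonist activity, with Mus musculus as the target (on this read-out higher numbers stand for an effect only at larger amounts of compound and lower numbers for an effect already at smaller amounts), compound 1 reaches only a limit, > 10 mg/kg. Compound 2 `CCCCCN1CCC(C(=O)Nc2cc(Cl)c(N)cc2OC)CC1` carries a pentyl chain. In this assay compound 2 likewise gives only a limit, > 10 mg/kg. Compound 3 `COc1cc(N)c(Cl)cc1NC(=O)C1CCN(Cc2ccccc2F)CC1` carries a 2-fluorobenzyl group. In this assay compound 3 gives only a limit, > 4 mg/kg. Compound 3 thus stands at one of two limits; the limit of > 10 mg/kg in this assay, at which 2 of the 3 values shown sit, and the limit of > 4 mg/kg in this assay, at which 1 of the 3 values shown sits, are all that is known, and none of the three values is a number. The steps a step that the two limits leave unreadable from compound 1 to compound 2, a step that the two limits leave unreadable from compound 1 to compound 3 and a step that the two limits leave unreadable from compound 2 to compound 3 are all unreadable between limits. Compound 4 `COc1cc(N)c(Cl)cc1NC(=O)C1CCN(Cc2ccccc2)CC1` differs from compound 3 by hydrogen in place of fluoro on an aromatic carbon. Within the data shown here, no measured step touches a fluoro on an aromatic carbon, so nothing read so far bears directly on this change, and every read-out sits at a limit. Compound 4 is therefore expected in the same region, with an estimated 8 mg/kg (range 2 mg/kg to 30 mg/kg). The step that the limit leaves unreadable from compound 3 to compound 4 is estimated as none beyond the scatter, most likely again reported as a limit.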

Compound 4, dose for half-maximal effect: 0.5 mg/kg
Compound 4: middle estimate off by 16-fold (1.20 log units), on the high side; the whole stated range lies above it.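

In this assay, the change from 2-fluorobenzyl to benzyl gives an at least 8.0-fold lower number from compound 3 to compound 4 (0.90 log units; beyond the scatter), so a single fluoro on this aromatic carbon, ortho to a large group, separates a limit from a firm number. Among these compounds, the benzyl group of compound 4 also stands clear of both alkyl chains, with an at least 20-fold lower number from compound 2 to compound 4 (1.30 log units; beyond the scatter) and an at least 20-fold lower number from compound 1 to compound 4 (1.30 log units; beyond the scatter), which shows for the first time that the group on the ring amine nitrogen can move this read-out. The full size of the fluoro step stays unknown because compound 3 rests on a limit: the limit of > 4 mg/kg in this assay, at which 1 of the 4 values shown sits.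

The steps among compound 1, compound 2 and compound 3 cannot be read. As far as these compounds go, it remains open whether a chloro or methyl on that same aromatic carbon, or a phenylethyl group in place of benzyl, would read like compound 4 or like compound 3.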